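Replacing Cyclohexyl with Pyridin-2-yl on a Shared Core

The source may hold more compounds than are shown below. What is called first, only, known or untested is meant among the compounds shown, and "the series" means these compounds.

Three analogues of one core have been tested in a functional assay on Jurkat cells (Homo sapiens) for inhibition, read by CCK-8 assay, with a stated time of 48 h; a lower number here means a stronger inhibitor of growth, a higher number a weaker inhibitor of growth. Compound 1 `Cc1ccccc1Nc1nc(Nc2cccnc2)ncc1Cl` gives 38600 nM in this assay. Compound 2 `Cc1ccccc1Nc1nc(NC2CCCCC2)ncc1Cl` reaches only the limit of the assay, > 100000 nM, so no number is known for it. Compound 3 `Cc1ccccc1Nc1nc(Nc2ccccc2)ncc1Cl` likewise sits at the limit, > 100000 nM. On the numbers shown compound 2 therefore stands at the weak end of the set, sharing the limit of > 100000 nM in this assay, at which 2 of the 3 values shown sit, with compound 3. The measured steps of an at least 2.5-fold higher number from compound 1 to compound 2 (0.41 log units; beyond the scatter) and an at least 2.5-fold higher number from compound 1 to compound 3 (0.41 log units; beyond the scatter) both run toward weaker inhibition, while a step that the two limits leave unreadable from compound 2 to compound 3 cannot be sized. Compound 4 `Cc1ccccc1Nc1nc(Nc2ccccn2)ncc1Cl` differs from compound 2 by pyridin-2-yl in place of cyclohexyl on a nitrogen on an aromatic ring. This change brings back a pyridinyl ring akin to the pyridin-3-yl that compound 1 carries, and the step of an at least 2.5-fold higher number from compound 1 to compound 2 (0.41 log units; beyond the scatter) suggests that undoing it should lower the number again. Compound 4 is therefore expected to show an at least 1.6-fold lower number from compound 2 to compound 4 (0.22 log units; that floor lies within the scatter), giving an estimated 60000 nM with a range from 20000 nM to 200000 nM.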

Compound 4, concentration for 50% growth inhibition: 20100 nM
Beside the measured number, compound 4's estimate is 3.0-fold (0.47 log units) above it; the measured number falls inside the stated range.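

In this assay, a direct comparison at this nitrogen now shows pyridin-2-yl ahead of both cyclohexyl, an at least 4.9-fold lower number from compound 2 to compound 4 (0.69 log units; beyond the scatter), and phenyl, an at least 4.9-fold lower number from compound 3 to compound 4 (0.69 log units; beyond the scatter). The two pyridinyl isomers are not separated, a 1.9-fold lower number from compound 1 to compound 4 (0.28 log units; within the scatter), so the placement of the ring nitrogen makes no readable difference between these two forms. Compound 2 and compound 3 both remain limits of the assay and not numbers, so the step between them cannot be read and the two steps to compound 4 give only floors: the limit of > 100000 nM in this assay, at which 2 of the 4 values shown sit.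

The compounds shown leave open whether pyridin-4-yl or a pyrimidinyl ring on this nitrogen would read like the two pyridinyl compounds. They also leave open whether an amine or a methoxy group on the pyridin-2-yl ring would lower the number further.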